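This account rests on a few compounds, and the source may have more. Where it says the series, first, only, none or still open, it means among the compounds named here.

Measured so far in an assay on CHO cells for displacement of a labelled ligand from C-X-C chemokine receptor type 3 (Homo sapiens), with a stated time of 60 min; on this read-out lower numbers stand for stronger inhibition and higher numbers for weaker inhibition: compound 1 `CCN(Cc1ccc(OCCN2C(=O)CCC2=O)c(C)c1)C(CC(=O)O)c1ccc(Cl)cc1` gives 424 nM; compound 2 `CCN(Cc1ccc(OCCn2c(=O)ccn(C)c2=O)c(C)c1)C(CC(=O)O)c1ccc(Cl)cc1` gives 428 nM.

Compound 2 and compound 1 lie within the scatter of each other, as the step of a 1.0-fold higher number from compound 1 to compound 2 (0.00 log units; within the scatter) shows. Compound 3 `Cc1cc(CN(C2CCC2)C(CC(=O)O)c2ccc(Cl)cc2)ccc1OCCn1c(=O)ccn(C)c1=O` differs from compound 2 by cyclobutyl in place of ethyl on an amine nitrogen. Among the measured compounds shown here, no measured step touches that amine nitrogen; the only known step changes a different group and is itself within the scatter, so it gives no direction for this change. Compound 3 is therefore expected to sit close to compound 2 in this assay, with a wide range to cover the absence of data. The estimate for compound 3 is 420 nM, between 140 nM and 1300 nM. The expected step is a 1.0-fold lower number from compound 2 to compound 3 (0.01 log units; within the scatter).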

Compound 3, half-maximal inhibitory concentration: 95 nM
Beside the measured number, compound 3's estimate is 4.4-fold (0.65 log units) above it; measured number outside the range, below it.
By their numbers in this assay, from the lowest: compound 3; then compounds 1 and 2 (each within the scatter of the next).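

Among the compounds shown here, the amine nitrogen is a position that responds in this assay: cyclobutyl in place of ethyl gives a 4.5-fold lower number from compound 2 to compound 3 (0.65 log units; beyond the scatter) and is the first change to move the number beyond the scatter. The earlier change in the other group, a 1.0-fold higher number from compound 1 to compound 2 (0.00 log units; within the scatter), gave no such signal. No evidence here bears on the reason for the step.

Open, as far as these compounds go, is whether a butyl chain, a cyclopropyl or a cyclopentyl on this amine nitrogen would match cyclobutyl. Also open, from the compounds shown here alone, is whether the step carries over to the core of compound 1.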